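The compounds below may be only part of what the source reports. "The series", "measured", "known", "first", "only" and "open" are said of these compounds alone.

Measured in a toxicity assay (Homo sapiens) for cytotoxicity, read by MTT assay, with a stated time of 48 h; a lower number here means a stronger inhibitor, a higher number a weaker inhibitor: compound 1 `O=C1C(O)=C(C(c2ccc(F)cc2)c2c[nH]c3ccccc23)C(=O)c2ccccc21` gives 65200 nM; compound 2 `COc1ccc(C(C2=C(O)C(=O)c3ccccc3C2=O)c2c[nH]c3ccccc23)cc1Br` gives 25200 nM; compound 3 `O=C1C(O)=C(C(c2cccs2)c2c[nH]c3ccccc23)C(=O)c2ccccc21` gives 31300 nM.

Compound 3 stands second highest of the three numbers: compound 2 is nearest, with a 1.2-fold higher number from compound 2 to compound 3 (0.09 log units; within the scatter), and compound 1 furthest, with a 2.1-fold lower number from compound 1 to compound 3 (0.32 log units; beyond the scatter). Compound 4 `O=C1C(O)=C(C(c2ccc(Cl)cc2)c2c[nH]c3ccccc23)C(=O)c2ccccc21` differs from compound 3 by 4-chlorophenyl in place of thiophen-2-yl on a saturated chain carbon bound to an aromatic carbon and a double-bonded ring carbon. Among the compounds with values here, no measured step makes this exact exchange. The closest is the reverse of the one that brought in thiophen-2-yl, a 2.1-fold lower number from compound 1 to compound 3 (0.32 log units; beyond the scatter), while the other exchange at the same place, a 2.6-fold lower number from compound 1 to compound 2 (0.41 log units; beyond the scatter), was of similar size. Compound 4 carries a six-membered aromatic ring of carbon only, as compound 1 does, and compound 1 gives 65200 nM. A modest step upward from compound 3 is therefore expected, a 1.4-fold higher number from compound 3 to compound 4 (0.16 log units; within the scatter), though it may stay within the scatter. Compound 4 is estimated at 45000 nM, ranging from 20000 nM to 100000 nM.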

Compound 4, half-maximal inhibitory concentration: 102000 nM
For compound 4 the middle estimate is 2.3-fold (0.36 log units) below the measured one; the whole stated range lies below it.
By their numbers in this assay, from the lowest: compounds 2 and 3 (each within the scatter of the next); then compounds 1 and 4 (each within the scatter of the next).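

In this assay, 4-chlorophenyl in place of thiophen-2-yl gives a 3.3-fold higher number from compound 3 to compound 4 (0.51 log units; beyond the scatter) and in place of 3-bromo-4-methoxyphenyl gives a 4.0-fold higher number from compound 2 to compound 4 (0.61 log units; beyond the scatter) at this place, both beyond the scatter. Chloro in place of fluoro on an aromatic carbon gives only a 1.6-fold higher number from compound 1 to compound 4 (0.19 log units; within the scatter) and stays within the scatter, so 4-chlorophenyl and 4-fluorophenyl both stand apart from the other two groups. No measurement given here accounts for these steps. As far as these compounds go, whether an amine or a carboxylic acid on the aromatic ring, or cyclohexyl in its place, would shift the number remains open.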